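Shifting a fluorine on compound 2: what to expect

A few compounds are considered here, and "the series" means these few. Any claim that something is new, unique, unknown or untested is made for them only; others in the source may bear on it.

Compound 2 `O=C1NC(c2ccccc2)(c2ccccc2)C(=O)N1CN1CCN(c2ccc(F)cc2)CC1` gives 100 mg/kg in a functional assay on the whole organism (strain CD1) with Mus musculus as the target, in the maximal electroshock model, with a stated time of 4 h (on this read-out higher numbers stand for an effect only at larger amounts of compound and lower numbers for an effect already at smaller amounts), and stands level with compound 1 `O=C1NC(c2ccccc2)(c2ccccc2)C(=O)N1CN1CCN(c2ccccc2)CC1`, which gives 100 mg/kg in this assay. The step of no change at the digits printed from compound 1 to compound 2 (within the scatter) lay within the scatter. Compound 3 `O=C1NC(c2ccccc2)(c2ccccc2)C(=O)N1CN1CCN(c2ccccc2F)CC1` differs from compound 2 by 2-fluorophenyl in place of 4-fluorophenyl on an amine nitrogen in a ring. Within the data shown here, only that single measured step bears on this change, and it showed no movement, so no step beyond the scatter is expected in this assay. Compound 3 is therefore estimated at 100 mg/kg, between 50 mg/kg and 200 mg/kg. This estimate means an expected step of no change at the digits printed from compound 2 to compound 3 (within the scatter).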

Compound 3, minimum effective dose: 30 mg/kg
Beside the measured number, compound 3's estimate is 3.3-fold (0.52 log units) above it; the measured number lies below the stated range.
By their numbers in this assay, from the lowest: compound 3; then compounds 1 and 2 (each within the scatter of the next).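

Moving the fluorine changes the result in this assay, where 2-fluorophenyl in place of 4-fluorophenyl gives a 3.3-fold lower number from compound 2 to compound 3 (0.52 log units; beyond the scatter). Fluoro in place of hydrogen on an aromatic carbon, which left the number unchanged in the earlier pair, gives a 3.3-fold lower number from compound 1 to compound 3 (0.52 log units; beyond the scatter) when it enters as 2-fluorophenyl, so the outcome of this replacement depends on where the fluorine sits. Nothing available explains this difference.

Still open, going by these compounds, is whether chloro or methoxy in place of the fluorine of 2-fluorophenyl would give a similar step. On these data alone, whether two fluorines on the same aromatic ring would do so also remains open.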